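Side-chain amine swap on two cores

The compounds below may be only part of what the source reports. "The series", "measured", "known", "first", "only" and "open" are said of these compounds alone.

Compound 1, `CCNCC(=O)Nc1cc(OC)ccc1C(=O)c1ccc2c(c1)C=CC(C)(C)O2`, gives 3110 nM in a functional assay on HeLa cells (Homo sapiens) for antiproliferative activity, read by MTT assay, with a stated time of 48 h; a lower number here means a stronger inhibitor, a higher number a weaker inhibitor. Compound 2, `COc1ccc(C(=O)c2ccc3c(c2)C=CC(C)(C)O3)c(NC(=O)CN(C)C)c1`, gives 1260 nM in this assay. Compound 3, `CCNCC(=O)Nc1cc(OC)ccc1C(=O)c1cc(OC)c(OC)c(OC)c1`, gives 2100 nM in this assay.

Compounds 1 and 2 share one core, compound 3 and compound 4 another; the difference between the two cores is not broken down here, and the values of compound 1 and compound 3 lie within the scatter of each other. The change dimethylamino in place of ethylamino on a saturated chain carbon bound to a carbonyl carbon produced a 2.5-fold lower number from compound 1 to compound 2 (0.39 log units; beyond the scatter). Compound 4, `COc1ccc(C(=O)c2cc(OC)c(OC)c(OC)c2)c(NC(=O)CN(C)C)c1`, is reached from compound 3 by dimethylamino in place of ethylamino on a saturated chain carbon bound to a carbonyl carbon, the same change at the same place. The step from compound 3 to compound 4 is expected to be about a 2.5-fold lower number from compound 3 to compound 4 (0.39 log units; beyond the scatter), resting on the step of a 2.5-fold lower number from compound 1 to compound 2 (0.39 log units; beyond the scatter) seen on the other core. Compound 4 is therefore estimated at 850 nM, expected between 400 nM and 1800 nM.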

Compound 4, half-maximal inhibitory concentration: 470 nM
Compound 4: the middle estimate sits 1.8-fold (0.26 log units) above what was measured; low and high end bracket the measured number.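

Dimethylamino in place of ethylamino on a saturated chain carbon bound to a carbonyl carbon again lowers the number in this assay, with a 4.5-fold lower number from compound 3 to compound 4 (0.65 log units; beyond the scatter). The step carries over from one core to the other, in direction and, within the scatter, in size: the same change on two cores in this assay, a 2.5-fold lower number (0.39 log units; beyond the scatter) from compound 1 to compound 2 and a 4.5-fold lower number (0.65 log units; beyond the scatter) from compound 3 to compound 4, 1.8-fold (0.26 log units) apart, within the scatter of two such steps. This rests on two pairs only, so it shows transfer between these two cores and says nothing about further cores or about why the change lowers the number.

From the compounds shown here alone, it remains open whether another amine in the same place, such as diethylamino or an unsubstituted amino group, would give a step of similar size. Also open, going by these compounds, is whether a longer chain carrying the dimethylamino keeps the step on both cores.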